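The source may report more compounds than this note shows. Statements on the series, on what has been measured and on what is new or still open speak of the compounds shown alone.

Compound 1 `Cn1c(/C=C/C(=O)c2ccc(Cl)cc2Cl)cc(Br)c1Br`: 1000 nM
Compound 2 `O=c1cc(-c2cc(Br)c(Br)[nH]2)oc2ccccc12`: 410 nM

Both compounds were tested in a functional assay on PA-1 cells (Homo sapiens) for cytotoxicity, read by MTT assay, with stated times of 6 h and 48 h; a lower number here means a stronger inhibitor, a higher number a weaker inhibitor. Compound 2, at 410 nM, holds the lower of the two numbers, and the gap to compound 1, at 1000 nM, lies beyond the usual scatter. These two structures differ in more than one place, so that gap cannot be pinned on any single change.

Compound 3 `Cn1c(-c2cc(=O)c3ccccc3o2)cc(Br)c1Br` keeps the core of compound 2 and changes one thing: methyl in place of hydrogen on an aromatic nitrogen. Within the data shown here, no measured pair shows this change alone, so the guidance is weak. Compound 1 also carries methyl on an aromatic nitrogen and gives 1000 nM, which hints at a modest move towards a higher number in this assay. The expected change is a 1.6-fold higher number from compound 2 to compound 3 (0.20 log units; within the scatter). For compound 3 the estimated value is 650 nM, with an expected range from 220 nM to 1900 nM.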

Compound 3, half-maximal inhibitory concentration: 600 nM
The estimate for compound 3 lay 1.1-fold (0.03 log units) above the measured number; low and high end bracket the measured number.
By their numbers in this assay, from the lowest: compounds 2, 3 and 1 (each within the scatter of the next, the first and the last beyond it).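

In this assay, among these compounds, the swap of hydrogen for methyl on the aromatic nitrogen gives a 1.5-fold higher number from compound 2 to compound 3 (0.17 log units; within the scatter) and so provides the first direct reading of this change on its own. In this pair, the hydrogen on that nitrogen is therefore not required for a number in this range, and a methyl is tolerated on a nitrogen next to both the ring atom that bears a bromo group and the ring atom that bears a large group. No measurement at hand explains why the two compounds read so alike.

From the compounds shown here alone, whether a group larger than methyl on this nitrogen, such as ethyl or a longer chain ending in an amine, would keep the number in the same range remains open. Going by these compounds, it is also open whether the same swap would read the same way on the core of compound 1.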